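A few compounds are considered here, and "the series" means these few. Any claim that something is new, unique, unknown or untested is made for them only; others in the source may bear on it.

Three compounds of this series have been run in a functional assay on MCF7 cells (Homo sapiens) for inhibition; on this read-out lower numbers stand for stronger inhibition and higher numbers for weaker inhibition. Compound 1 `N#CC1CN1C(=O)Nc1ccc(Cl)c(Cl)c1` gives 4400 nM, compound 2 `N#CC1CN1C(=O)Nc1ccc([N+](=O)[O-])cc1` gives 3000 nM, and compound 3 `CCNC(=O)N1CC1C#N` gives 10000 nM. Compound 2 carries the lowest of the three numbers; its number and that of compound 1 lie within the scatter of each other, while compound 3 sits beyond the scatter with a higher number. Compound 4 `N#CC1CN1C(=O)Nc1ccc(S(N)(=O)=O)cc1` has not been run. It differs from compound 2 in one place: sulfamoyl in place of nitro on an aromatic carbon. Going by the values given here, no measured pair covers this change, so only compound 2 with its 3000 nM anchors the expectation. In this assay a step of modest size at most is expected for this change, leaning toward a higher number, and quite possibly none beyond the scatter. Compound 4 is estimated at 4000 nM, with a range from 1500 nM to 12000 nM. The expected step is a 1.3-fold higher number from compound 2 to compound 4 (0.12 log units; within the scatter).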

Compound 4, half-maximal inhibitory concentration: > 15000 nM
Compound 4 was reported as a limit; the forecaster's own chance of this, stated with the estimate: 20%; middle value at least 3.7-fold (0.57 log units) away from the limit.
By their numbers in this assay, from the lowest: compounds 2 and 1 (each within the scatter of the next); then compound 3. At a limit, above all of these: compound 4.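

In this assay, sulfamoyl in place of nitro on the aromatic carbon para to a group of 8 heavy atoms gives an at least 5.0-fold higher number from compound 2 to compound 4 (0.69 log units; beyond the scatter), the first step read at this position, so the number here depends on the group carried. Compound 4 gives > 15000 nM, which is a limit and not a number: the limit of > 15000 nM in this assay, at which 1 of the 4 values shown sits. The full size of the step therefore stays unread.

Open, from the compounds shown here alone, is whether methylsulfonyl, which lacks the sulfamoyl nitrogen, would give a number like that of compound 2. Also open, going by these compounds, is how an amine or a carboxylic acid at this position would read.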